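Thiophene-bearing dihydropyrimidinone thioesters and esters at the adenosine A2b receptor

This account rests on a few compounds, and the source may have more. Where it says the series, first, only, none or still open, it means among the compounds named here.

Measured so far:
compound 1 `COC(=O)C1=C(C)N(C)C(=O)NC1c1ccsc1` — 26%
compound 2 `CCOC(=O)C1=C(C)N(C)C(=O)NC1c1ccsc1` — 53%
compound 3 `CCSC(=O)C1=C(C)NC(=O)NC1c1cccs1` — 1%

In an assay on membranes from HEK293 cells for displacement of a labelled ligand from adenosine receptor A2b (Homo sapiens), read by scintillation counting, with a stated time of 30 min, tested at 1 uM (a lower number here means less inhibition, a higher number more inhibition at the concentration tested (going by the name of the read-out)), compound 2 gives the highest of the three numbers, compound 3 the lowest. Within the data shown here, the one single-point step measured, (methyl in place of hydrogen on a saturated chain carbon bound to an oxygen next to a carbonyl group), gave a number 27 percentage points higher from compound 1 to compound 2 (beyond the scatter). The cores of compound 1 and compound 3 differ in more than one place; that difference is not broken down here. Compound 4 `CC1=C(C(=O)SC(C)C)C(c2cccs2)NC(=O)N1` is not yet measured; it differs from compound 3 by methyl in place of hydrogen on a saturated chain carbon bound to a saturated chain carbon and a sulfur. This is the same kind of change as in compound 2, but around a different place: a carbon bound to a saturated chain carbon and a sulfur rather than to an oxygen next to a carbonyl group. Resting on a number 27 percentage points higher from compound 1 to compound 2 (beyond the scatter), a smaller gain is expected for compound 4 in this assay, about a number 14 percentage points higher from compound 3 to compound 4 (beyond the scatter), because compound 3 starts from 1%. Compound 4 is estimated at 15%, between 0% and 40%.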

Compound 4, a percentage reported as inhibition, at one concentration (the size of the read-out at that concentration, not a potency): 1%
Estimate against measurement, compound 4: 14 percentage points above, and the stated range covers the measured number.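

Placing this methyl on the core of compound 3 gives no change at the digits printed from compound 3 to compound 4 (within the scatter) in this assay. The gain seen on the core of compound 1 does not carry over to the core of compound 3: the same change on two cores in this assay, a number 27 percentage points higher (beyond the scatter) from compound 1 to compound 2 and no change at the digits printed (within the scatter) from compound 3 to compound 4, 27 percentage points apart, beyond the scatter of two such steps

This shows that the step depends on the core for these two pairs only; the cores differ in more than one place, so the data cannot tell which difference matters, and two pairs give no rule for other cores.

Still open, going by these compounds, is whether a longer chain, such as butyl, or a benzyl group in place of ethylsulfanyl's ethyl would change the number for the core of compound 3. Also open, on these data alone, is how an isopropyl ester would read on the core of compound 1.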